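Notes on a methoxy step from compound 3 to compound 4

The compounds below may be only part of what the source reports. "The series", "measured", "known", "first", "only" and "open" are said of these compounds alone.

Measured in a functional assay on MIA PaCa-2 cells (Homo sapiens) for antiproliferative activity, read by WST assay, with a stated time of 72 h; a higher number here means a weaker inhibitor, a lower number a stronger inhibitor:
compound 1 `c1ccc(-c2noc(-c3cc4ccccc4[nH]3)n2)cc1`: 22000 nM
compound 2 `Fc1ccc2[nH]c(-c3nc(-c4ccccc4)no3)cc2c1`: 33600 nM
compound 3 `Clc1ccc2[nH]c(-c3nc(-c4ccccc4)no3)cc2c1`: 23100 nM

Compound 3 stands second highest of the three numbers, nearest to compound 1 and furthest from compound 2; all three lie within the scatter of each other, as a 1.1-fold higher number from compound 1 to compound 3 (0.02 log units; within the scatter) and a 1.5-fold lower number from compound 2 to compound 3 (0.16 log units; within the scatter) show, and a 1.5-fold higher number from compound 1 to compound 2 (0.18 log units; within the scatter) likewise. Compound 4 `COc1ccc(-c2noc(-c3cc4cc(Cl)ccc4[nH]3)n2)cc1` differs from compound 3 by methoxy in place of hydrogen on an aromatic carbon. For the measured compounds named here, no measured step touches that ring or a methoxy group; the steps at hand, all halogen-for-hydrogen exchanges on the other ring, stayed within the scatter. Nothing here argues for a shift beyond the scatter, so compound 4 is expected to give about 20000 nM in this assay, between 7000 nM and 55000 nM, a step of a 1.2-fold lower number from compound 3 to compound 4 (0.06 log units; within the scatter).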

Compound 4, half-maximal inhibitory concentration: 7800 nM
The estimate for compound 4 lay 2.6-fold (0.41 log units) above the measured number; the measured number falls inside the stated range.
By their numbers in this assay, from the lowest: compound 4; then compounds 1, 3 and 2 (each within the scatter of the next).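

Methoxy in place of hydrogen, on the six-membered aromatic ring of carbon only and para to a large group, gives a 3.0-fold lower number from compound 3 to compound 4 (0.47 log units; beyond the scatter) and is the first step in the series to lie beyond the scatter. The halogen exchanges among compound 1, compound 2 and compound 3 all stayed within it. No measurement shown explains the change at this position.

From the compounds shown here alone, whether an amine, a carboxylic acid or a longer alkoxy chain at the same place would give a similar step remains open. So does whether methoxy would give this step on the core of compound 1 or compound 2.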